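A Methoxy Group Added to Compound 2

This account rests on a few compounds, and the source may have more. Where it says the series, first, only, none or still open, it means among the compounds named here.

In an ADME assay on HEK293 cells (Homo sapiens) for cytotoxicity, read by MTT assay, with a stated time of 48 h (on this read-out lower numbers stand for stronger inhibition and higher numbers for weaker inhibition), compound 1 (`COc1ccc(-c2nc(C)c(C(=O)CSc3nc(-c4cccc(OC)c4)c(C#N)c(=O)[nH]3)s2)cc1`) gives 95400 nM and compound 2 (`Cc1nc(-c2ccccc2)sc1C(=O)CSc1nc(-c2ccc(Cl)c(Cl)c2)c(C#N)c(=O)[nH]1`) gives 85100 nM. These two numbers lie within the usual scatter of repeated measurements, so compound 2 stands level with compound 1 and the two cannot be ranked.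

Compound 3 (`COc1ccc(-c2nc(C)c(C(=O)CSc3nc(-c4ccc(Cl)c(Cl)c4)c(C#N)c(=O)[nH]3)s2)cc1`) has not yet been measured. It differs from compound 2 in one place: methoxy in place of hydrogen on an aromatic carbon, para to a large group, which turns phenyl into 4-methoxyphenyl (methoxy in place of hydrogen on an aromatic carbon). Among the measured compounds shown here, no measured pair shows this change on its own, so the data offer no direct guide. Compound 1 also carries a 4-methoxyphenyl group and gives 95400 nM, so no shift beyond the scatter is expected in this assay. The estimated change is a 1.0-fold lower number from compound 2 to compound 3 (0.00 log units; within the scatter). For compound 3 the expected value is 85000 nM, within an estimated range from 40000 nM to 170000 nM.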

Compound 3, half-maximal inhibitory concentration: 45600 nM
The estimate for compound 3 lay 1.9-fold (0.27 log units) above the measured number; the range from low to high includes it.
By their numbers in this assay, from the lowest: compounds 3, 2 and 1 (each within the scatter of the next, the first and the last beyond it).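

In this assay, methoxy in place of hydrogen on an aromatic carbon, para to a large group, gives a 1.9-fold lower number from compound 2 to compound 3 (0.27 log units; within the scatter), so turning phenyl into 4-methoxyphenyl produces no shift that can be told from the scatter. Compound 1 and compound 3 both carry 4-methoxyphenyl, and 3,4-dichlorophenyl in place of 3-methoxyphenyl gives a 2.1-fold lower number from compound 1 to compound 3 (0.32 log units; beyond the scatter), a modest step and the only one here that clears the scatter. Nothing available explains either result.

The compounds shown leave open whether an amine or a carboxylic acid in that same place, para to a large group, would shift the number beyond the scatter. They also leave open whether the step from 3-methoxyphenyl to 3,4-dichlorophenyl would keep its size with phenyl in place of 4-methoxyphenyl.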